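Bromo on the Amide-Bearing Ring: Working Notes Toward Compound 4

The source may report more compounds than this note shows. Statements on the series, on what has been measured and on what is new or still open speak of the compounds shown alone.

Measured compounds:
compound 1 `Cc1ccnc(OCc2ccc(F)cc2)c1C(=O)NC1CCCCCC1` — 580 nM
compound 2 `O=C(NC1CCCCCC1)c1c(-c2ccccc2)c(Br)cn(Cc2ccc(F)cc2)c1=O` — > 10000 nM, a limit of the assay
compound 3 `O=C(NC1CCCCCC1)c1c(-c2ccccc2)ccn(Cc2ccc(F)cc2)c1=O` — > 10000 nM, a limit of the assay

In a functional assay on U-937 cells (Homo sapiens) for inhibition, read by scintillation counting, with a stated time of 15 min (a higher number here means a weaker inhibitor, a lower number a stronger inhibitor), compound 1 is the only one of the three that gives a number. Compound 2 gives only a limit. Compound 3 likewise gives only a limit. Among the measured compounds shown here, both sit at the limit of > 10000 nM in this assay, at which 2 of the 3 values shown sit, so the one measured instance of the change, a step that the two limits leave unreadable from compound 3 to compound 2, is bromo in place of hydrogen on an aromatic carbon.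

The difference between the core of compound 1 and that of compound 3 is not broken down here.

Compound 4 `Cc1c(Br)cnc(OCc2ccc(F)cc2)c1C(=O)NC1CCCCCC1` is not yet measured in this assay. It differs from compound 1 by bromo in place of hydrogen on an aromatic carbon. This is the same kind of change as from compound 3 to compound 2, not the same: there the carbon was ortho to a phenyl group, meta to a 4-fluorobenzyl group, meta to a cycloheptylcarbamoyl group and para to a group of 1 heavy atom; here it is ortho to a methyl group, meta to a large group and para to a (4-fluorobenzyl)oxy group.

With the measured instance unreadable, the expectation for compound 4 rests on compound 1 at 580 nM alone: a step of a 1.3-fold lower number from compound 1 to compound 4 (0.11 log units; within the scatter) within the usual scatter is expected. Compound 4 is thus estimated at 450 nM, between 150 nM and 2000 nM.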

Compound 4, half-maximal inhibitory concentration: 620 nM
Compound 4: the middle estimate sits 1.4-fold (0.14 log units) below what was measured; the measured number falls inside the stated range.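

In this assay, bromo in place of hydrogen on the core of compound 1, ortho to a methyl group and para to a (4-fluorobenzyl)oxy group, leaves no readable difference: the result is a 1.1-fold higher number from compound 1 to compound 4 (0.03 log units; within the scatter). Among the compounds shown here, on the core of compound 3 the same change cannot be read, since compound 2 and compound 3 each give only a limit of the assay: the limit of > 10000 nM in this assay, at which 2 of the 4 values shown sit. The one readable instance therefore speaks for the core of compound 1 alone, and it shows nothing about whether the outcome of the change carries from one core to the other.

The compounds shown leave open whether a different group on the same aromatic carbon, such as an amine, a carboxylic acid or a longer chain, would also stay within the scatter of compound 1. They also leave open what bromo does on the core of compound 3 when the parent compound gives a number rather than a limit.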